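This account rests on a few compounds, and the source may have more. Where it says the series, first, only, none or still open, it means among the compounds named here.

The compounds below were measured in an ADME assay on a cell-free system (plasma, Rattus norvegicus) (a lower number here means a smaller unbound share, a higher number a larger unbound share of the compound), and gave these results.

- compound 1 `CCCS(=O)(=O)c1cccc(C#Cc2cc(Cl)ccc2OCC(=O)O)c1` gives 0.01 in this measurement
- compound 2 `CN(C)S(=O)(=O)c1ccc(F)c(C#Cc2cc(Cl)ccc2OCC(=O)O)c1` gives 0.007 in this measurement
- compound 3 `CC(C)S(=O)(=O)c1ccc(Cl)c(C#Cc2cc(Cl)ccc2OCC(=O)O)c1` has the entry "not determined" (no result reported) in this measurement

Compound 2 at 0.007 lies within the usual scatter of compound 1 at 0.01 in this assay and cannot be told apart from it. Compound 3 adds no number to the comparison. Compound 4 `CCCS(=O)(=O)c1ccc(F)c(C#Cc2cc(Cl)ccc2OCC(=O)O)c1` has not yet been measured. Its difference from compound 2 is propyl in place of dimethylamino on a sulfonyl sulfur. Among the measured compounds shown here, no measured pair of compounds differs in one place only, so this change has no direct precedent here. The expectation rests on compound 1, which also carries propylsulfonyl and gives 0.01 in this assay and stays within the scatter of compound 2. The expected step is no change at the digits printed from compound 2 to compound 4 (within the scatter) and it should lie within the scatter, with no clear direction. For compound 4 the estimated unbound fraction is 0.007 (range 0.004 to 0.012).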

Compound 4, unbound fraction: 0.004
The estimate for compound 4 lay 1.8-fold (0.24 log units) above the measured number; low and high end bracket the measured number.
By their numbers in this assay, from the lowest: compounds 4, 2 and 1 (each within the scatter of the next, the first and the last beyond it).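

In this assay, propyl in place of dimethylamino on a sulfonyl sulfur gives a 1.8-fold lower number from compound 2 to compound 4 (0.24 log units; within the scatter), so this exchange at the sulfonyl sulfur cannot be told apart from no change. Fluoro in place of hydrogen on an aromatic carbon gives a 2.5-fold lower number from compound 1 to compound 4 (0.40 log units; beyond the scatter), a modest step and the only one among these compounds that clears the scatter. Nothing on record explains either step.

Going by these compounds, compound 2 has no partner that differs from it by the fluoro alone, so it remains open whether this step also holds with dimethylsulfamoyl on the sulfonyl sulfur. Also open, on these data alone, is how this assay would respond to a methoxy group in place of fluoro, or to a longer chain than propyl on the sulfonyl sulfur.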